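Cytotoxicity follow-up: from compound 1 to compound 3

This account rests on a few compounds, and the source may have more. Where it says the series, first, only, none or still open, it means among the compounds named here.

The series is read in an ADME assay on HCT-116 cells (Homo sapiens) for cytotoxicity, read by CellTiter-Glo, with a stated time of 72 h; a lower number here means a stronger inhibitor, a higher number a weaker inhibitor. Compound 1 `COC(=O)c1ccc(S(=O)(=O)N2CCC(N3CCC(C)CC3)CC2)cc1` gives only a limit there: in this assay compound 1 gives > 5000 nM, which is the limit (the limit of > 5000 nM in this assay, at which 1 of the 2 values shown sits). Compound 2 `CC1CCN(C2CCN(S(=O)(=O)c3cccc4ccccc34)CC2)CC1` likewise gives a limit: in this assay compound 2 gives > 10000 nM, the limit (the limit of > 10000 nM in this assay, at which 1 of the 2 values shown sits). Both measured compounds thus sit at assay limits rather than at numbers, so compound 1 stands without a number of its own, and neither limit ranks one compound against the other.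

Compound 3 `CC1CCN(C2CCN(S(=O)(=O)c3ccc(OC(F)(F)F)cc3)CC2)CC1` has not yet been run. It differs from compound 1 as follows: trifluoromethoxy in place of methoxycarbonyl on an aromatic carbon. Within the data shown here, no measured step between compounds exists, so the size of this change cannot be read from any comparison. Compound 1 shows only the limit > 5000 nM. On that basis compound 3 is expected to return a limit again rather than a number, with no shift beyond the scatter, the expected step being a step that the limit leaves unreadable from compound 1 to compound 3. Compound 3 is estimated at about 10000 nM, in the range 3000 nM to 30000 nM.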

Compound 3, half-maximal inhibitory concentration: > 5000 nM
Compound 3: only a limit was reported (the forecaster's own chance of this, stated with the estimate: 80%); the middle value is on the limit's open side.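

In this assay compound 3 gives > 5000 nM as a limit, not a number. Among these compounds, compound 1 also stands at a limit, so no step between compound 1 and compound 3 can be read. The compounds shown leave open how any of them ranks against another, with all three values at limits: the limit of > 5000 nM in this assay, at which 2 of the 3 values shown sit.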